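Swapping 3-nitrophenyl for 4-methylphenyl on a shared core

The source may hold more compounds than are shown below. What is called first, only, known or untested is meant among the compounds shown, and "the series" means these compounds.

In a functional assay on CCRF-CEM cells (Homo sapiens) for antiproliferative activity (on this read-out higher numbers stand for weaker inhibition and lower numbers for stronger inhibition), compound 1 (`COc1cc(C(=O)c2sc(-c3cccc([N+](=O)[O-])c3)cc2N)cc(OC)c1OC`) gives 5.9 nM as the lowest number of the three measured, ahead of compound 3 (`COc1cc(C(=O)c2sc(-c3ccc(F)cc3)cc2N)cc(OC)c1OC`) at 15 nM and compound 2 (`COc1cc(C(=O)c2sc(-c3ccncc3)cc2N)cc(OC)c1OC`) at 110 nM in this small set. Compound 4 (`COc1cc(C(=O)c2sc(-c3ccc(C)cc3)cc2N)cc(OC)c1OC`) keeps the core of compound 1 and changes one group, with 4-methylphenyl in place of 3-nitrophenyl on an aromatic carbon as the full account of the swap. Two measured swaps at this same place bear on it. Pyridin-4-yl gave a 19-fold higher number from compound 1 to compound 2 (1.27 log units; beyond the scatter) in the number, but its ring is not of carbon only. The 4-fluorophenyl of compound 3 has one six-membered aromatic ring of carbon only, as the entering 4-methylphenyl does, and it gave a 2.5-fold higher number from compound 1 to compound 3 (0.41 log units; beyond the scatter) as the closer guide. For the measured compounds named here, no compound with a 4-methylphenyl has been measured yet, so this guide is loose. A modest move to a higher number is expected, estimated as a 2.4-fold higher number from compound 1 to compound 4 (0.38 log units; beyond the scatter) with real uncertainty. Compound 4 is estimated at 14 nM with an expected range of 5 nM to 40 nM for now.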

Compound 4, half-maximal inhibitory concentration: 15 nM
The estimate for compound 4 lay 1.1-fold (0.03 log units) below the measured number; the measured number falls inside the stated range.
By their numbers in this assay, from the lowest: compound 1; then compounds 3 and 4 (each within the scatter of the next); then compound 2.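

In this assay, 4-methylphenyl in place of 3-nitrophenyl gives a 2.5-fold higher number from compound 1 to compound 4 (0.41 log units; beyond the scatter) and so lands level with the 4-fluorophenyl of compound 3, since methyl in place of fluoro gives no change at the digits printed from compound 3 to compound 4 (within the scatter) at this position. Set against the pyridin-4-yl group, 4-methylphenyl gives a 7.3-fold lower number from compound 2 to compound 4 (0.87 log units; beyond the scatter) and thus adds a third compound, alongside compound 1 and compound 3, whose ring of carbon only carries a lower number than the ring of compound 2. Nothing measured here explains these differences.

The compounds shown leave open whether the lower number of compound 1 goes with the nitro group or with its place on the ring, a question that 4-nitrophenyl and 3-methylphenyl would help to separate. From the compounds shown here alone, how an amine or a carboxylic acid on this phenyl ring would fare also remains open.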